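Aryl substituent changes on the shared core: methyl to chloro

This account rests on a few compounds, and the source may have more. Where it says the series, first, only, none or still open, it means among the compounds named here.

The series carries the core of compound 3 `Cc1cc(C)cc(-c2c(C)nn(-c3nc(-c4ccc(Cl)c(Cl)c4)c(SC(C)C)s3)c2C(=O)O)c1` with a varied aryl group. In a functional assay on BJAB cells (Homo sapiens) for antiproliferative activity, with a stated time of 4 days (on this read-out lower numbers stand for an effect already at smaller amounts and higher numbers for an effect only at larger amounts of compound), compound 1 `Cc1ccc(-c2c(C)nn(-c3nc(-c4ccc(Cl)c(Cl)c4)c(SC(C)C)s3)c2C(=O)O)cc1` gives 3800 nM, compound 2 `COc1ccc(-c2c(C)nn(-c3nc(-c4ccc(Cl)c(Cl)c4)c(SC(C)C)s3)c2C(=O)O)cc1` gives 2100 nM, and compound 3 gives 2700 nM. Compound 3 stands second highest of the three numbers, yet every pair lies within the scatter: a 1.8-fold lower number from compound 1 to compound 2 (0.26 log units; within the scatter), a 1.4-fold lower number from compound 1 to compound 3 (0.15 log units; within the scatter), a 1.3-fold higher number from compound 2 to compound 3 (0.11 log units; within the scatter). Compound 4 `Cc1cc(Cl)cc(-c2c(C)nn(-c3nc(-c4ccc(Cl)c(Cl)c4)c(SC(C)C)s3)c2C(=O)O)c1` differs from compound 3 by chloro in place of methyl on an aromatic carbon. Going by the values given here, no measured step exchanges methyl for chloro, so the change is untested directly. What bears on it is that the three changes on this aryl ring, methoxy for methyl and the shift to the 3,5-dimethylphenyl pattern, all stayed within the scatter in this assay. For compound 4 the expectation is therefore a step in this assay of about a 1.1-fold lower number from compound 3 to compound 4 (0.03 log units; within the scatter), no direction beyond the scatter. The estimated value for compound 4 in this assay is 2500 nM, with a range from 1000 nM to 6000 nM.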

Compound 4, half-maximal effective concentration: 663 nM
Compound 4: the middle estimate sits 3.8-fold (0.58 log units) above what was measured; measured number outside the range, below it.
By their numbers in this assay, from the lowest: compound 4; then compounds 2, 3 and 1 (each within the scatter of the next).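

Among the changes on this aryl group, chloro in place of methyl is the only one shown to move the number in this assay beyond the scatter: a 4.1-fold lower number from compound 3 to compound 4 (0.61 log units; beyond the scatter). The two other steps to the 3-chloro-5-methylphenyl group run the same way, a 3.2-fold lower number from compound 2 to compound 4 (0.50 log units; beyond the scatter) and a 5.7-fold lower number from compound 1 to compound 4 (0.76 log units; beyond the scatter), which sets compound 4 apart from compounds 1, 2 and 3, whose numbers all lie within the scatter of each other. No measurement shown here accounts for this step.

Whether the step belongs to chloro specifically remains open, since the compounds shown do not include bromo or nitrile at this place. They also leave open whether a second chloro in place of the remaining methyl would lower the number further.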